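Swapping phenoxy for 2-methylphenyl on a carbonyl carbon

The source may report more compounds than this note shows. Statements on the series, on what has been measured and on what is new or still open speak of the compounds shown alone.

In a functional assay on HCT-116 cells (Homo sapiens) for cytotoxicity, read by crystal violet staining and colony formation, with a stated time of 7 days (a lower number here means a stronger inhibitor, a higher number a weaker inhibitor), compound 1 `C=CCOc1cc(O)c2c(c1)OC(c1ccc(O)cc1)CC2=O`, with allyl on an oxygen on an aromatic ring, gives 1910 nM. Compound 2 `O=C(Oc1ccccc1)Oc1cc(O)c2c(c1)OC(c1ccc(O)cc1)CC2=O`, with phenoxycarbonyl on that oxygen, gives 20000 nM, the higher of the two numbers. Going by the values given here, the only measured step, a 10-fold higher number from compound 1 to compound 2 (1.02 log units; beyond the scatter), is large and beyond the scatter.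

Compound 3 `Cc1ccccc1C(=O)Oc1cc(O)c2c(c1)OC(c1ccc(O)cc1)CC2=O` has not yet been measured. It has 2-methylphenyl in place of phenoxy on a carbonyl carbon. Cut one bond further out, this reads phenoxycarbonyl to (2-methylphenyl)carbonyl, so the change lies within the group introduced in the measured step. Among the compounds with values here, that step shows that the number can shift widely at this oxygen, but it does not test the present swap, and no measured pair keeps the carbonyl while varying what sits on it. A modest move toward a lower number is therefore expected, though it may not clear the scatter, and the value of compound 1, 1910 nM, serves as a rough lower guide. The expected change is a 2.5-fold lower number from compound 2 to compound 3 (0.40 log units; beyond the scatter). For compound 3 the estimated value is 8000 nM, with an expected range from 2500 nM to 30000 nM.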

Compound 3, half-maximal inhibitory concentration: 6030 nM
The estimate for compound 3 lay 1.3-fold (0.12 log units) above the measured number; the range from low to high includes it.
By their numbers in this assay, from the lowest: compound 1; then compound 3; then compound 2.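

In this assay, going by these compounds alone, this is the first measured pair that keeps the carbonyl and varies what sits on it, and the swap of 2-methylphenyl for phenoxy on that carbonyl carbon is a modest step beyond the scatter (a 3.3-fold lower number from compound 2 to compound 3 (0.52 log units; beyond the scatter)). What is attached to the carbonyl carbon therefore moves the number, so the large rise seen earlier at this oxygen is not fixed by the carbonyl alone. Even so, the new group does not close the gap to allyl on the oxygen (a 3.2-fold higher number from compound 1 to compound 3 (0.50 log units; beyond the scatter)), and compound 1 keeps the lowest number of the three, while nothing at hand explains either step.

The two groups differ both in the oxygen of phenoxy and in the methyl of 2-methylphenyl, so the compounds shown leave open which of these carries the step, a question that plain phenyl on the carbonyl carbon would help to settle. Also open, on these data alone, is whether an amine or a longer chain in that place would bring the number down to that of compound 1 (1910 nM).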